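Trading the Hydroxy Group for Methyl on the Side Chain

The source may hold more compounds than are shown below. What is called first, only, known or untested is meant among the compounds shown, and "the series" means these compounds.

Compound 1 `Cn1ncc(Cl)c1-c1cc(C(=O)N[C@@H]2CN[C@H](CC(=O)NC3CC3)C[C@H]2c2ccc(Cl)c(Cl)c2)oc1Cl`: 3.95 nM
Compound 2 `Cn1ncc(Cl)c1-c1cc(C(=O)N[C@@H]2CN[C@H](CC(=O)NC3CCC3)C[C@H]2c2ccc(Cl)c(Cl)c2)oc1Cl`: 7.98 nM
Compound 3 `Cn1ncc(Cl)c1-c1cc(C(=O)N[C@@H]2CN[C@H](CCO)C[C@H]2c2ccc(Cl)c(Cl)c2)oc1Cl`: 2.74 nM

All three compounds were tested in an assay for inhibition of RAC-alpha serine/threonine-protein kinase (Homo sapiens), read by HTRF, with a stated time of 1 h; a lower number here means a stronger inhibitor, a higher number a weaker inhibitor. Compound 3 has the lowest number of the three, yet its gap to compound 1 is small: a 1.4-fold lower number from compound 1 to compound 3 (0.16 log units; within the scatter). Compound 2 sits further off: a 2.9-fold lower number from compound 2 to compound 3 (0.46 log units; beyond the scatter). Between the two amides themselves there is a modest separation: a 2.0-fold higher number from compound 1 to compound 2 (0.31 log units; beyond the scatter).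

Compound 4 `CCC[C@@H]1C[C@@H](c2ccc(Cl)c(Cl)c2)[C@H](NC(=O)c2cc(-c3c(Cl)cnn3C)c(Cl)o2)CN1` differs from compound 3 in one place: methyl in place of hydroxy on a saturated chain carbon, two bonds along the chain from a saturated ring carbon. Cut one bond further out, the same change reads hydroxymethyl to ethyl, or 2-hydroxyethyl to propyl.

Among the compounds with values here, no measured step removes a hydroxy outright, so none bears on it directly. What the measured steps do show is that this side chain has accepted quite different groups with only small consequences: the replacement of cyclopropylcarbamoyl by hydroxymethyl stayed within the scatter, and the replacement of cyclobutylcarbamoyl by hydroxymethyl gave only a modest shift. On that basis, compound 4 is expected to lose little, if anything, with a step of a 1.8-fold higher number from compound 3 to compound 4 (0.26 log units; within the scatter). The estimate for compound 4 in this assay is 5 nM, within a range from 2 nM to 15 nM.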

Compound 4, half-maximal inhibitory concentration: 10.4 nM
Estimate against measurement, compound 4: 2.1-fold (0.32 log units) below; the measured number falls inside the stated range.
By their numbers in this assay, from the lowest: compounds 3 and 1 (each within the scatter of the next); then compounds 2 and 4 (each within the scatter of the next).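

Within the data shown here, compound 4 gives the first direct reading on the hydroxy itself, and its loss is not free (a 3.8-fold higher number from compound 3 to compound 4 (0.58 log units; beyond the scatter)). The change swaps one heavy atom for another and removes one hydrogen-bond donor and one acceptor, yet this modest step is larger than any step among the first three compounds, so this side chain is less indifferent than those compounds suggested. The plain propyl chain also separates the two amides: it lies beyond the scatter from the cyclopropyl amide (a 2.6-fold higher number from compound 1 to compound 4 (0.42 log units; beyond the scatter)) but within the scatter of the cyclobutyl amide (a 1.3-fold higher number from compound 2 to compound 4 (0.12 log units; within the scatter)), and nothing shown explains why the hydroxy step has this size.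

This is a single pair on a single core, so it cannot be said whether the same change would cost as much elsewhere. A methoxy or an amine on the same chain carbon would show whether another group can match the hydroxy, while a 3-hydroxypropyl chain would show whether the hydroxy's distance from the ring counts.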